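Chloro for hydrogen on the benzyl ring of compound 3

This account rests on a few compounds, and the source may have more. Where it says the series, first, only, none or still open, it means among the compounds named here.

Three compounds of this series carry a measured value in an assay for inhibition of Amine oxidase [flavin-containing] A (Rattus norvegicus); a higher number here means a weaker inhibitor, a lower number a stronger inhibitor. Compound 1 `Cc1cccc(COc2ccc(-c3nn(CCC#N)c(=O)o3)cc2)c1` gives 20000 nM. Compound 2 `N#CCCn1nc(-c2ccc(OCc3cccc(Cl)c3)cc2)oc1=O` gives 7400 nM. Compound 3 `N#CCCN1N=C(c2ccc(OCc3ccccc3)cc2)OCC1=O`, which carries the six-membered ring core with a plain benzyl group, gives 160000 nM, the highest of the three numbers; compound 1 sits below it and compound 2 further below it, both beyond the scatter.

The next compound, compound 4 `N#CCCN1N=C(c2ccc(OCc3cccc(Cl)c3)cc2)OCC1=O`, keeps the core of compound 3 and differs from it in one place: chloro in place of hydrogen on an aromatic carbon.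

Among the measured compounds shown here, only one measured step touches this position on the benzyl ring: a 2.7-fold lower number from compound 1 to compound 2 (0.43 log units; beyond the scatter), a chloro entering for methyl rather than for hydrogen, on the five-membered ring core. For the measured compounds named here, no pair in this assay shows chloro entering for hydrogen directly, and no pair shows any substituent change on the core of compound 3. Going by the values given here, the step from compound 1 to compound 2 is the only guide, so a modest lowering of the number is expected for compound 4, with a wide range because the core differs.

The estimate for compound 4 is 60000 nM, between 20000 nM and 170000 nM, meaning a step of a 2.7-fold lower number from compound 3 to compound 4 (0.43 log units; beyond the scatter) is expected.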

Compound 4, half-maximal inhibitory concentration: 13000 nM
Estimate against measurement, compound 4: 4.6-fold (0.66 log units) above, and the stated range ends above it.
By their numbers in this assay, from the lowest: compounds 2, 4 and 1 (each within the scatter of the next, the first and the last beyond it); then compound 3.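

Among the compounds shown here, on the core of compound 3, benzyl to 3-chlorobenzyl gives a 12-fold lower number from compound 3 to compound 4 (1.09 log units; beyond the scatter) in this assay and is the first reading of chloro entering for hydrogen, as well as the first substituent change on this core. The earlier step on the benzyl ring, a 2.7-fold lower number from compound 1 to compound 2 (0.43 log units; beyond the scatter) on another core, is smaller, but chloro replaces methyl there, so the two steps differ in both the leaving group and the core and do not isolate a single effect. The new information is that this position on the benzyl ring can produce a large step on the core of compound 3, and no measurement here accounts for its size.

As far as these compounds go, how a methoxy or trifluoromethyl group at this position would compare with chloro on the core of compound 3 remains open, as does what the parent benzyl compound on the core of compound 1 would show for the same change from hydrogen to chloro. Also open, from the compounds shown here alone, is whether this step would hold if a longer chain or an amine stood in place of the nitrile chain on the core.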